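The source may hold more compounds than are shown below. What is called first, only, known or untested is meant among the compounds shown, and "the series" means these compounds.

Measured compounds:
compound 1, `CS(=O)(=O)c1cncc(-c2ccn3nc(N)nc3c2)c1`, 39800000 nM in an assay on isolated protein for inhibition of phosphatidylinositol 4,5-bisphosphate 3-kinase catalytic subunit beta isoform (Homo sapiens); a lower number here means a stronger inhibitor, a higher number a weaker inhibitor
compound 2, `Nc1nc2cc(-c3cncc(S(N)(=O)=O)c3)ccn2n1`, 39800000 nM in this assay
compound 3, `CNS(=O)(=O)c1cncc(-c2ccn3nc(N)nc3c2)c1`, 39800000 nM in this assay

Compound 3 stands level with the other two: no change at the digits printed from compound 1 to compound 3 (within the scatter) and no change at the digits printed from compound 2 to compound 3 (within the scatter). All three carry a sulfonyl group on the same shared core and differ only in what sits on the sulfonyl sulfur or the sulfonamide nitrogen, and none of those exchanges moved the read-out, as no change at the digits printed from compound 1 to compound 2 (within the scatter) also shows.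

Compound 4, `Nc1nc2cc(-c3cncc(S(=O)(=O)NCc4ccccc4)c3)ccn2n1`, is not yet measured. It differs from compound 3 by phenyl in place of hydrogen on a saturated chain carbon bound to a sulfonamide nitrogen. For the measured compounds named here, the only step bearing on it is the one adding a methyl on the sulfonamide nitrogen, which showed no change. A larger group at the same place is therefore expected to give no change at the digits printed from compound 3 to compound 4 (within the scatter), that is none beyond the scatter. Compound 4 is estimated at 39800000 nM, with a range from 10000000 nM to 39800000 nM.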

Compound 4, half-maximal inhibitory concentration: 25100000 nM
For compound 4 the middle estimate is 1.6-fold (0.20 log units) above the measured one; the range from low to high includes it.
By their numbers in this assay, from the lowest: compounds 4, 1, 2 and 3 (each within the scatter of the next).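

For the compounds shown here, compound 4 extends what the earlier compounds showed: they carried nothing larger than a methyl at this place, yet benzyl on the sulfonamide nitrogen still leaves the numbers in this assay level, within the scatter (a 1.6-fold lower number from compound 3 to compound 4 (0.20 log units; within the scatter); a 1.6-fold lower number from compound 2 to compound 4 (0.20 log units; within the scatter); a 1.6-fold lower number from compound 1 to compound 4 (0.20 log units; within the scatter)). No measurement shown here offers an explanation for this. Still open, on these data alone, is whether a longer chain carrying the phenyl, or a carboxylic acid or an amine in place of the phenyl, would move the read-out. Also open, as far as these compounds go, is whether any change to the shared core would.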